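Replacing the Ring Amine Substituent with a Small Amide

The compounds below may be only part of what the source reports. "The series", "measured", "known", "first", "only" and "open" are said of these compounds alone.

Compound 1 `CN1CCc2nc(C#Cc3ccccc3)sc2C1`: > 10000 nM
Compound 2 `CCN1CCc2nc(C#Cc3ccccc3)sc2C1`: 1200 nM
Compound 3 `C(#Cc1nc2c(s1)CN(C1CCCCC1)CC2)c1ccccc1`: > 10000 nM

In an assay on HEK293 cells for negative allosteric modulation of metabotropic glutamate receptor 5 (Homo sapiens), read by FLIPR, with a stated time of 1 h (a higher number here means a weaker inhibitor, a lower number a stronger inhibitor), compound 2 gives 1200 nM. Compound 1 sits at a limit of the assay, > 10000 nM. Compound 3 also sits at a limit, > 10000 nM, so its potency is bounded only from one side, and two of the three values share that limit (the limit of > 10000 nM in this assay, at which 2 of the 3 values shown sit). Among the measured steps, an at least 8.3-fold lower number from compound 1 to compound 2 (0.92 log units; beyond the scatter), while an at least 8.3-fold higher number from compound 2 to compound 3 (0.92 log units; beyond the scatter), and a step that the two limits leave unreadable from compound 1 to compound 3.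

Compound 4 `O=C(C1CC1)N1CCc2nc(C#Cc3ccccc3)sc2C1` is not yet measured. It differs from compound 3 by cyclopropylcarbonyl in place of cyclohexyl on an amine nitrogen in a ring. Going by the values given here, no measured step covers a change of this kind, since each of the measured steps alters only the size of a saturated group on that nitrogen. The expectation for compound 4 therefore rests only loosely on the measured compounds, and compound 4 is expected to show an at least 2.5-fold lower number from compound 3 to compound 4 (0.39 log units; beyond the scatter). Compound 4 is estimated at 4000 nM, within a wide range of 500 nM to 30000 nM.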

Compound 4, half-maximal inhibitory concentration: 290 nM
Beside the measured number, compound 4's estimate is 14-fold (1.14 log units) above it; the measured number lies below the stated range.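

In this assay, going by these compounds alone, the amine nitrogen in the ring carries a group that is not a saturated one for the first time: cyclopropylcarbonyl, with its carbonyl, gives a 4.1-fold lower number from compound 2 to compound 4 (0.62 log units; beyond the scatter) and so stands here with a lower number than the ethyl group. Heavy-atom count does not separate the groups on this nitrogen, as cyclopropylcarbonyl, with 5 heavy atoms against 6 for cyclohexyl, gives an at least 34-fold lower number from compound 3 to compound 4 (1.53 log units; beyond the scatter) and, in place of the much smaller methyl, gives an at least 34-fold lower number from compound 1 to compound 4 (1.53 log units; beyond the scatter) as well. Both of these larger steps start from a limit and not from a number: the limit of > 10000 nM in this assay, at which 2 of the 4 values shown sit.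

The compounds shown do not separate the carbonyl from the cyclopropyl ring, which an acetyl group or a plain cyclopropyl on this nitrogen would do. Going by these compounds, whether a urea or a sulfonamide in the same place behaves like this amide also stays open.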